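Adding a methoxy group to compound 2

A few compounds are considered here, and "the series" means these few. Any claim that something is new, unique, unknown or untested is made for them only; others in the source may bear on it.

- Compound 1 `CC(C)(CNC(=O)c1ccc2ccccc2c1)CC1=C(O)C(=O)c2ccccc2C1=O` reads 46700 nM
- Compound 2 `COC1=C(CC(C)(C)CNC(=O)c2ccccc2OC)C(=O)c2ccccc2C1=O` reads 27300 nM
- Compound 3 `COc1ccccc1C(=O)NCC(C)(C)CC1=C(O)C(=O)c2ccccc2C1=O` reads 31200 nM

In an ADME assay on Vero cells (Chlorocebus sabaeus) for cytotoxicity, read by fluorescence, with a stated time of 4 days (on this read-out lower numbers stand for stronger inhibition and higher numbers for weaker inhibition), compound 2 cannot be told apart from its two relatives. The comparison with its closest relative gives a 1.1-fold higher number from compound 2 to compound 3 (0.06 log units; within the scatter), and the values of compound 1 and compound 2 also lie within the scatter of each other.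

The next structure is compound 4 `COC1=C(CC(C)(C)CNC(=O)c2cc(OC)ccc2OC)C(=O)c2ccccc2C1=O`, which has methoxy in place of hydrogen on an aromatic carbon, meta to a large group and para to a methoxy group. This turns 2-methoxyphenyl into 2,5-dimethoxyphenyl (methoxy in place of hydrogen on an aromatic carbon).

Going by the values given here, no measured step makes this same change, so there is no direct reading of it. Two steps offer indirect guidance. Swapping naphthalen-2-yl for 2-methoxyphenyl on the carbonyl carbon alters the same part of the molecule and gives a 1.5-fold lower number from compound 1 to compound 3 (0.18 log units; within the scatter). Removing the methyl from the oxygen on the unsaturated carbon alters a different part and gives a 1.1-fold higher number from compound 2 to compound 3 (0.06 log units; within the scatter). Neither step left the scatter, so a step beyond it is not expected here, though three compounds are thin evidence. The expected change is a 1.0-fold higher number from compound 2 to compound 4 (0.01 log units; within the scatter). Compound 4 is estimated at 28000 nM, with an expected range from 14000 nM to 55000 nM.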

Compound 4, half-maximal inhibitory concentration: 36200 nM
Compound 4: middle estimate off by 1.3-fold (0.11 log units), on the low side, and the stated range covers the measured number.
By their numbers in this assay, from the lowest: compounds 2, 3, 4 and 1 (each within the scatter of the next).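

Going by these compounds alone, this is the first direct reading of a change on this aromatic ring: in this assay, methoxy in place of hydrogen, meta to a large group and para to a methoxy group, gives a 1.3-fold higher number from compound 2 to compound 4 (0.12 log units; within the scatter). The earlier steps shown here either exchanged the whole naphthalen-2-yl group for 2-methoxyphenyl or touched a different part of the molecule, so they could say little about this single position, whereas this step shows that a methoxy placed here leaves the number within the scatter of the parent compound in this cytotoxicity read-out. No supporting measurement bears on this result, so the data offer no explanation for it.

The compounds shown leave open whether a different group at this position, such as an amine or a carboxylic acid, would also stay within the scatter, since methoxy is the only group on record here. They also leave open whether the 2,5-dimethoxyphenyl group would behave the same way on the hydroxy form of the core, the form that compound 3 carries.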